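This account rests on a few compounds, and the source may have more. Where it says the series, first, only, none or still open, it means among the compounds named here.

Measured so far in an assay on NIH3T3 cells with Urotensin-2 receptor (Homo sapiens) as the target; on this read-out higher numbers stand for an effect only at larger amounts of compound and lower numbers for an effect already at smaller amounts:
- compound 1 `CN(C)CCC(OC(=O)c1ccc(-c2ccccc2)cc1)c1ccc(Cl)cc1` gives 525 nM
- compound 2 `CN(C)CCC(OC(=O)c1cc2ccccc2n1C)c1ccc(Cl)cc1` gives 1380 nM
- compound 3 `Cc1ccccc1C(=O)NC(CCN(C)C)c1ccc(Cl)cc1` gives 3550 nM

Compound 3 stands highest of the three numbers in this assay. Its nearest neighbour is compound 2, whose value is lower by a margin beyond the scatter; compound 1 lies furthest from it, again beyond the scatter. Among the compounds with values here, compound 3 is also the only amide of the set, the other two being esters, so no measured pair isolates a single change, and no step between measured compounds can be quoted.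

Compound 4 `COc1cccc(C(=O)NC(CCN(C)C)c2ccc(Cl)cc2)c1C` is not yet measured. It differs from compound 3 in one place: methoxy in place of hydrogen on an aromatic carbon, the rest of the molecule unchanged.

With no measured step of this kind in the series, the expectation rests on the general weight of such a small addition. A step from compound 3 to compound 4 of about a 1.4-fold lower number from compound 3 to compound 4 (0.15 log units; within the scatter) is expected in this assay, which is within or only slightly beyond the scatter, with direction uncertain and a slight lean toward a lower number. Compound 4 is therefore estimated at 2500 nM in this assay, with a range from 800 nM to 8000 nM.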

Compound 4, half-maximal effective concentration: 4270 nM
Compound 4: the middle estimate sits 1.7-fold (0.23 log units) below what was measured, within the range that was stated.
By their numbers in this assay, from the lowest: compound 1; then compound 2; then compounds 3 and 4 (each within the scatter of the next).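

Within the data shown here, the replacement of hydrogen by methoxy on the aromatic carbon ortho to a methyl group and meta to a large group gives in this assay the first single-place step, a 1.2-fold higher number from compound 3 to compound 4 (0.08 log units; within the scatter) and so places compound 3 and compound 4 within the scatter of each other. At this position of the amide series, the methoxy group with its two heavy atoms and one hydrogen-bond acceptor therefore brings no readable separation from hydrogen in this assay, a finding limited to this one substitution. No independent measurement bears on this result, and the step alone offers no explanation for it.

From the compounds shown here alone, whether this position also accepts a hydroxy group, an ethoxy group, a longer chain such as butoxy, an amine or a carboxylic acid remains open, as does whether methoxy would behave in the same way without the neighbouring methyl group. Going by these compounds, the esters compound 1 and compound 2 differ from the amides in more than one place, so the contribution of the amide link itself also remains open.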